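This account rests on a few compounds, and the source may have more. Where it says the series, first, only, none or still open, it means among the compounds named here.

Measured compounds:
compound 1, `Nc1ccccc1NC(=O)c1ccc(CSC(=S)N2CCc3ccccc32)cc1`: 44%
compound 2, `Nc1ccccc1NC(=O)c1ccc(CSC(=S)N2CCN(c3cccnc3)CC2)cc1`: 27.6%

In a functional assay on MGC-803 cells (Homo sapiens) for antiproliferative activity, read by CCK-8 assay, with a stated time of 72 h, tested at 2 uM (a higher number here means a stronger effect of the compound at the concentration tested, a lower number a weaker effect), compound 1 gives 44%, the higher of the two numbers recorded. Compound 2 gives 27.6% in this assay, a number that lies below that of compound 1 by more than the usual scatter of repeated measurements. The two measured compounds share the same core and differ only in the group carried on the thiocarbonyl carbon, so the available numbers offer one comparison and no chain of single changes.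

Compound 3, `CN(C(=S)SCc1ccc(C(=O)Nc2ccccc2N)cc1)c1cccnc1`, has not yet been measured in this assay. It differs from compound 1 in this way: methyl(pyridin-3-yl)amino in place of 2,3-dihydro-1H-indol-1-yl on a thiocarbonyl carbon. The group that enters shares a pyridine ring with the group carried by compound 2, while the group that leaves is found only in compound 1, the stronger of the two measured compounds.

On that basis the step from compound 1 to compound 3 in this assay is expected to run downward, by an amount about at the edge of the scatter, as a number 12 percentage points lower from compound 1 to compound 3 (beyond the scatter). Compound 3 is therefore estimated to give 32% in this assay, with a range from 18% to 48%.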

Compound 3, a percentage reported as inhibition, at one concentration (the size of the read-out at that concentration, not a potency): 46.1%
Estimate against measurement, compound 3: 14.1 percentage points below; the measured number falls inside the stated range.
By their numbers in this assay, from the lowest: compound 2; then compounds 1 and 3 (each within the scatter of the next).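

In this assay, methyl(pyridin-3-yl)amino in place of 2,3-dihydro-1H-indol-1-yl on a thiocarbonyl carbon gives a number 2.1 percentage points higher from compound 1 to compound 3 (within the scatter), so at this position the five-membered non-aromatic ring of the group that leaves is not needed to keep the number within the scatter. The new result also shows that a pyridine ring does not by itself go with the lower number, since compound 3 gives 46.1% and compound 2, which also carries such a ring, gives 27.6%, although the two differ in the rest of the group on the thiocarbonyl carbon. No measurement is available that accounts for the outcome of this change.

The compounds shown leave open whether the pyridine nitrogen matters at all, which a phenyl ring in place of the pyridin-3-yl would address, and whether an ethyl or a cyclopropyl group in place of the methyl would hold the number. They also leave open whether the effects of these compounds would compare in the same way at other concentrations, since each number comes from one concentration only.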